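The compounds below may be only part of what the source reports. "The series", "measured", "known", "first", "only" and "open" are said of these compounds alone.

- Compound 1 `O=S(=O)(c1ccc(Br)cc1)c1nc2ccccc2nc1N1CCCC(O)C1`: 3430 nM
- Compound 2 `O=S(=O)(c1ccc(F)cc1)c1nc2ccccc2nc1N1CCCC(O)C1`: 2620 nM

In a functional assay on HL-60 cells (Homo sapiens) for cytotoxicity, read by MTT assay, with a stated time of 72 h (a lower number here means a stronger inhibitor, a higher number a weaker inhibitor), the two measured compounds stand level, with a 1.3-fold lower number from compound 1 to compound 2 (0.12 log units; within the scatter). Compound 3 `O=S(=O)(c1ccc(F)cc1)c1nc2ccccc2nc1N1CCC(O)CC1` keeps the fluoro group of compound 2 but carries 4-hydroxypiperidin-1-yl in place of 3-hydroxypiperidin-1-yl on an aromatic carbon. Going by the values given here, the only measured step swapped bromo for fluoro elsewhere, so it says nothing direct about this change. No direction can be drawn from the data, and no step beyond the scatter is expected. The estimate for compound 3 is 2800 nM, with an expected range from 1100 nM to 7000 nM. That is an expected 1.1-fold higher number from compound 2 to compound 3 (0.03 log units; within the scatter).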

Compound 3, half-maximal inhibitory concentration: 1450 nM
Compound 3: middle estimate off by 1.9-fold (0.29 log units), on the high side; low and high end bracket the measured number.
By their numbers in this assay, from the lowest: compounds 3, 2 and 1 (each within the scatter of the next, the first and the last beyond it).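

In this assay, going by these compounds alone, this is the first change at the group on the aromatic carbon next to the ring nitrogen: 4-hydroxypiperidin-1-yl in place of 3-hydroxypiperidin-1-yl gives a 1.8-fold lower number from compound 2 to compound 3 (0.26 log units; within the scatter). The two groups have the same atoms, joined differently, and here they stand level. No supporting data bear on this result. Going by these compounds, what a piperidine without the hydroxyl, a morpholine, or an amino group in place of the hydroxyl would give stays open, as does whether the same level result holds with bromo in place of fluoro.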